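This account rests on a few compounds, and the source may have more. Where it says the series, first, only, none or still open, it means among the compounds named here.

Compound 2 `Oc1ccc(-c2cc(-c3ccc(Cl)cc3)nc(-c3cccs3)c2)cc1` gives 6450 nM in a functional assay on T47D cells (Homo sapiens) for cytotoxicity, read by CCK-8 assay and cell counting, with a stated time of 2 days; on this read-out higher numbers stand for weaker inhibition and lower numbers for stronger inhibition. Going by the values given here, compound 1 `Oc1cccc(-c2cc(-c3ccc(Cl)cc3)nc(-c3cccs3)c2)c1` gives 10500 nM, and the only measured step, a 1.6-fold lower number from compound 1 to compound 2 (0.21 log units; within the scatter), leaves the two numbers within the scatter of each other, so neither stands clearly apart. Compound 3 `Oc1ccc(-c2cc(-c3ccc(Cl)cc3)nc(-c3ccco3)c2)cc1` differs from compound 2 by furan-2-yl in place of thiophen-2-yl on an aromatic carbon. No measured step touches this ring exchange, since the one step shown concerns the hydroxyphenyl group instead, so the expected change is none beyond the scatter, a 1.0-fold higher number from compound 2 to compound 3 (0.00 log units; within the scatter). Compound 3 is therefore estimated at 6500 nM, between 2500 nM and 17000 nM.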

Compound 3, half-maximal inhibitory concentration: 6260 nM
Compound 3: middle estimate off by 1.0-fold (0.02 log units), on the high side; measured number inside the range.
By their numbers in this assay, from the lowest: compounds 3, 2 and 1 (each within the scatter of the next).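

The exchange of thiophen-2-yl for furan-2-yl, on the carbon next to the ring nitrogen, is the first change shown at this position, and a 1.0-fold lower number from compound 2 to compound 3 (0.01 log units; within the scatter) in this assay is the step it gives. For this pair, replacing the sulfur of the five-membered aromatic ring with oxygen therefore leaves the number within the scatter. No supporting evidence bears on why this is so. Still open, on these data alone, is what an amine or a carboxylic acid would do at this position, in place of these two rings. The compounds shown also leave open whether furan-2-yl and thiophen-2-yl would match alongside 3-hydroxyphenyl.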